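The source may hold more compounds than are shown below. What is called first, only, known or untested is meant among the compounds shown, and "the series" means these compounds.

Of the compounds shown here, three sharing a core have been tested in a functional assay on SW480 cells (Homo sapiens) for antiproliferative activity, read by MTT assay, with a stated time of 48 h (on this read-out higher numbers stand for weaker inhibition and lower numbers for stronger inhibition), and none of them gave a number. Compound 1 `CCCCCC(CCO)n1cnc2cncnc21` reads > 50000 nM, which is a limit of the assay. Compound 2 `CCCCCCC(CCO)n1cnc2c(NC)ncnc21` reads > 50000 nM, again a limit. Compound 3 `CCCCCCC(CCO)n1cnc2c(N(C)C)ncnc21` reads > 50000 nM, also a limit, so compound 3 has no measured potency of its own to start from.

The next structure is compound 4 `CCCCCCC(CCO)n1cnc2cncnc21`. It arises from compound 3 by putting hydrogen in place of dimethylamino on an aromatic carbon. Among the measured compounds shown here, only one measured step bears on this change: a step that the two limits leave unreadable from compound 2 to compound 3. That step has no readable size, so it offers no guide to how much this group matters. The overall picture is the limit of > 50000 nM in this assay, at which 3 of the 3 values shown sit. For the measured compounds named here, nothing measured so far points to a gain in this assay, so no step beyond the scatter is expected, and another limit is the most likely result. The expectation rests on compound 3, whose > 50000 nM is a limit. The expected change is a number no higher from compound 3 to compound 4 (the limit leaves the size open). For compound 4 the estimated value is 50000 nM, with an expected range from 20000 nM to 100000 nM.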

Compound 4, half-maximal inhibitory concentration: > 50000 nM
Compound 4 ended at the assay's limit; the forecaster's own chance of this, stated with the estimate: 80%; the middle value sits exactly at the limit.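

Compound 4 stops at a limit of the assay, as do compound 1, compound 2 and compound 3, so none of the steps joining compound 4 to these three can be read. The picture stays as it was: the limit of > 50000 nM in this assay, at which 4 of the 4 values shown sit.

The compounds shown leave open how potent each one really is, and which change to the shared core would give a measurable number.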